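Working notes: from compound 2 to compound 3

The source may report more compounds than this note shows. Statements on the series, on what has been measured and on what is new or still open speak of the compounds shown alone.

Measured so far in a functional assay on MCF7 cells (Homo sapiens) for inhibition, with a stated time of 72 h; a lower number here means a stronger inhibitor, a higher number a weaker inhibitor
- compound 1 `NC1CCC(Nc2nc(NCc3ccc(-c4cccc(F)c4)cc3)c3ncn(C4CCCC4)c3n2)CC1` gives 293 nM
- compound 2 `NC1CCC(Nc2nc(NCc3ccc(-n4cccn4)cc3)c3ncn(C4CCCC4)c3n2)CC1` gives 139 nM

For the measured compounds named here, the one measured step is a 2.1-fold lower number from compound 1 to compound 2 (0.32 log units; beyond the scatter) and it is modest, which leaves compound 2 with the lower of the two numbers. The next structure is compound 3 `NC1CCC(Nc2nc(NCc3ccc(-c4cccs4)nc3)c3ncn(C4CCCC4)c3n2)CC1` with 6-(thiophen-2-yl)pyridin-3-yl in place of 4-(1H-pyrazol-1-yl)phenyl on a saturated chain carbon bound to a nitrogen on an aromatic ring. Going by the values given here, the measured step bears on this only in part: it exchanged a single ring, whereas both rings change here, and no measured compound carries either entering ring. The estimated change is a 1.4-fold higher number from compound 2 to compound 3 (0.16 log units; within the scatter) and a small rise is expected rather than a clear one, with the direction uncertain. For compound 3 an estimate of 200 nM is expected (range 70 nM to 600 nM).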

Compound 3, half-maximal inhibitory concentration: 92 nM
Estimate against measurement, compound 3: 2.2-fold (0.34 log units) above; low and high end bracket the measured number.
By their numbers in this assay, from the lowest: compounds 3 and 2 (each within the scatter of the next); then compound 1.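

In this assay, 6-(thiophen-2-yl)pyridin-3-yl in place of 4-(1H-pyrazol-1-yl)phenyl gives a 1.5-fold lower number from compound 2 to compound 3 (0.18 log units; within the scatter), so at this position both rings can change together without a step beyond the scatter. For the compounds shown here, the earlier step exchanged only one ring, whereas here a five-membered aromatic ring with sulfur and a six-membered aromatic ring with a hetero atom enter at once, with the counts of heavy atoms and hydrogen-bond acceptors unchanged. No evidence is available to explain this result.

The compounds shown leave open which of the two entering rings accounts for the step, as the thiophene and the pyridine change together here. Also open, on these data alone, is how an amine or a carboxylic acid on the 6-(thiophen-2-yl)pyridin-3-yl group would read in this assay.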